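A few compounds are considered here, and "the series" means these few. Any claim that something is new, unique, unknown or untested is made for them only; others in the source may bear on it.

For the measured compounds named here, compound 3 `CS/C(=N\C(=O)c1cc(-c2ccccc2)nc2ccccc12)NC(=O)c1cc(-c2ccccc2)nc2ccccc12` gives the lowest number among the three measured members: in a functional assay on PC-3 cells (Homo sapiens) for cytotoxicity, read by MTT assay, with a stated time of 72 h (a lower number here means a stronger inhibitor of growth, a higher number a weaker inhibitor of growth), compound 3 gives 7480 nM. Compound 1 `O=C(/N=C(/NC(=O)c1cc(-c2ccccc2)nc2ccccc12)[Se]Cc1ccccc1)c1cc(-c2ccccc2)nc2ccccc12` gives 39300 nM in this assay, and compound 2 `O=C(/N=C(/NC(=O)c1cccs1)[Se]Cc1ccccc1)c1cccs1` gives 49900 nM. Compound 4 `C[Se]/C(=N\C(=O)c1cc(-c2ccccc2)nc2ccccc12)NC(=O)c1cc(-c2ccccc2)nc2ccccc12` is the next member to be run in this assay. The change from compound 3 is a group of 2 heavy atoms (1 carbon, 1 selenium; no ring) in place of a group of 2 heavy atoms (1 carbon, 1 sulfur; no ring), on a carbon with a double bond to nitrogen. Going by the values given here, the only measured step touching this position is a 5.3-fold lower number from compound 1 to compound 3 (0.72 log units; beyond the scatter). That step swaps both the chalcogen and the carbon group at once, and the measured compounds do not show the exchange of sulfur for selenium on its own. The step from compound 3 to compound 4 is therefore expected to be small, likely within the scatter, as a 1.0-fold higher number from compound 3 to compound 4 (0.00 log units; within the scatter). Compound 4 is estimated at 7500 nM, between 3000 nM and 19000 nM.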

Compound 4, concentration for 50% growth inhibition: 3970 nM
For compound 4 the middle estimate is 1.9-fold (0.28 log units) above the measured one, and the stated range covers the measured number.
By their numbers in this assay, from the lowest: compounds 4 and 3 (each within the scatter of the next); then compounds 1 and 2 (each within the scatter of the next).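

In this assay, selenium in place of the sulfur of methylsulfanyl, on a carbon with a double bond to nitrogen, gives a 1.9-fold lower number from compound 3 to compound 4 (0.28 log units; within the scatter) and so leaves the two chalcogens unseparated in this pair. With selenium held constant, hydrogen in place of phenyl on the saturated chain carbon bound to selenium gives a 9.9-fold lower number from compound 1 to compound 4 (1.00 log units; beyond the scatter) and separates the effect of the carbon group from that of the chalcogen. No evidence is available to explain either step. Still open, going by these compounds, is whether a longer chain or an amine on the selenium would read like compound 4 or like compound 1.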